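This account rests on a few compounds, and the source may have more. Where it says the series, first, only, none or still open, it means among the compounds named here.

Three compounds have been measured in a functional assay (aorta) with Rattus norvegicus as the target; on this read-out higher numbers stand for weaker inhibition and lower numbers for stronger inhibition:

Compound 1 `COc1ccc(CN(C)CCCCOc2ccc(S(=O)(=O)c3c(C(C)C)cn4ccccc34)cc2)cc1OC`: 14.6 nM
Compound 2 `CC(C)c1cn2ccccc2c1S(=O)(=O)c1ccc(OCCCN2CCC(c3ccccc3)CC2)cc1`: 80.9 nM
Compound 3 `CCCCCCCCN(CCCCCCCC)CCCOc1ccc(S(=O)(=O)c2c(C(C)C)cn3ccccc23)cc1`: 30100 nM

Compound 2, at 80.9 nM, has the second highest number of the three. It lies above compound 1, and far below compound 3, which gives 30100 nM.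

The next compound to be tested is compound 4 `COc1ccc(NCCCOc2ccc(S(=O)(=O)c3c(C(C)C)cn4ccccc34)cc2)cc1OC`. Its change from compound 2 is (3,4-dimethoxyphenyl)amino in place of 4-phenylpiperidin-1-yl on a saturated chain carbon, three bonds along the chain from an oxygen on an aromatic ring. The swap falls on a saturated chain carbon, three bonds along the chain from an oxygen on an aromatic ring.

Within the data shown here, no two measured compounds differ in only one place, so the size of this step can only be judged loosely. Compound 1 also carries a 3,4-dimethoxyphenyl group, joined differently, and gives 14.6 nM, so that group is not expected to cost much on its own. Compound 3, at 30100 nM, shows how far the number can move when the amine part is changed. On balance, a moderate rise in the number, meaning somewhat weaker inhibition, is expected, and it may only just clear the scatter.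

For compound 4 the estimated value is 200 nM, with an expected range of 40 nM to 1000 nM. That estimate corresponds to an expected 2.5-fold higher number from compound 2 to compound 4 (0.39 log units; beyond the scatter).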

Compound 4, half-maximal inhibitory concentration: 396 nM
Beside the measured number, compound 4's estimate is 2.0-fold (0.30 log units) below it; the range from low to high includes it.
By their numbers in this assay, from the lowest: compound 1; then compound 2; then compound 4; then compound 3.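

In this assay, among these compounds, placing (3,4-dimethoxyphenyl)amino in place of 4-phenylpiperidin-1-yl on a saturated chain carbon, three bonds along the chain from an oxygen on an aromatic ring, gives a 4.9-fold higher number from compound 2 to compound 4 (0.69 log units; beyond the scatter) as the first step between compounds that differ in one place. The position therefore responds to the group it carries, with weaker inhibition beyond the scatter, although the step is modest and compound 4 still gives a measurable inhibitory value. The change alters several things at once, as the entering group has no non-aromatic ring and carries a hydrogen-bond donor and oxygen atoms that the leaving group lacks, and nothing available here accounts for the rise.

The compounds shown leave open which of these differences matters, and a methyl group on the amine nitrogen of compound 4 would test the role of the amine hydrogen. They also leave open how a plain phenylamino group without the two methoxy groups, or a longer chain carrying the same (3,4-dimethoxyphenyl)amino group, would read in this assay.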